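This account rests on a few compounds, and the source may have more. Where it says the series, first, only, none or still open, it means among the compounds named here.

Compound 1, `COc1ccc(C(/C=C/c2ccc(F)cc2)=N/O)cc1`: 13500 nM
Compound 2, `COc1ccc(/C=C/C(=N\O)c2ccc(OC)cc2)cc1`: 2170000 nM
Compound 3, `O/N=C(\C=C\c1ccc(F)cc1)c1ccc(Br)cc1`: 20300 nM

Of the compounds shown here, three have been measured in an ADME assay on cells (Mus musculus, strain Balb/c) for cytotoxicity, read by MTT assay, with a stated time of 48 h; a lower number here means that less compound is tolerated, a higher number that more compound is tolerated. Going from compound 1 to compound 2 the change is methoxy in place of fluoro on an aromatic carbon, and it produces a 160-fold higher number from compound 1 to compound 2 (2.21 log units; beyond the scatter). Compound 3 differs from compound 1 in its core by bromo in place of methoxy on an aromatic carbon, which gives a 1.5-fold higher number from compound 1 to compound 3 (0.18 log units; within the scatter), so compound 1 and compound 3 sit close together while compound 2 lies far above both.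

Compound 4, `COc1ccc(/C=C/C(=N\O)c2ccc(Br)cc2)cc1`, has not yet been measured in this assay . It differs from compound 3 by methoxy in place of fluoro on an aromatic carbon, the same change as that made from compound 1 to compound 2, now carried out on the core of compound 3. Since that change earlier brought a 160-fold higher number from compound 1 to compound 2 (2.21 log units; beyond the scatter), a step of similar direction and size is expected for compound 4, estimated as a 99-fold higher number from compound 3 to compound 4 (1.99 log units; beyond the scatter). This expectation rests on a single prior instance on a different core, so the range is kept wide. In this assay compound 4 is therefore estimated at 2000000 nM, between 300000 nM and 6000000 nM.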

Compound 4, half-maximal cytotoxic concentration: 23700 nM
The estimate for compound 4 lay 84-fold (1.93 log units) above the measured number; measured number outside the range, below it.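

In this assay, among the compounds shown here, methoxy in place of fluoro gives a 1.2-fold higher number from compound 3 to compound 4 (0.07 log units; within the scatter), so the large rise seen on the core of compound 1 does not carry over to the core of compound 3: the same change on two cores in this assay, a 160-fold higher number (2.21 log units; beyond the scatter) from compound 1 to compound 2 and a 1.2-fold higher number (0.07 log units; within the scatter) from compound 3 to compound 4, 140-fold (2.14 log units) apart, beyond the scatter of two such steps Read the other way, bromo in place of methoxy gives a 92-fold lower number from compound 2 to compound 4 (1.96 log units; beyond the scatter), although the same change made almost no difference when fluoro was the other substituent: the same change on two cores in this assay, a 1.5-fold higher number (0.18 log units; within the scatter) from compound 1 to compound 3 and a 92-fold lower number (1.96 log units; beyond the scatter) from compound 2 to compound 4, 140-fold (2.14 log units) apart, beyond the scatter of two such steps These four compounds show that neither change has a fixed effect, since the high number belongs to compound 2 alone, the only one with two methoxy groups, but they do not show why the effects fail to carry over or whether the result of compound 2 would hold up in related compounds.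

The compounds shown leave open whether the high number requires methoxy on both aromatic rings. They also leave open whether another group in one of those places, such as ethoxy, chloro or an amine, would give a similar number.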